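Moving the Fluorine to a New Place on the Benzyl Ring

The source may hold more compounds than are shown below. What is called first, only, known or untested is meant among the compounds shown, and "the series" means these compounds.

Measured compounds:
compound 1, `O=C1CC(c2ccccc2OCc2ccc(F)cc2)Oc2ccccc21`: 42.1%
compound 2, `CC(C)CCOc1ccccc1C1CC(=O)c2ccccc2O1`: 43.6%
compound 3, `O=C1CC(c2ccccc2OCc2ccccc2)Oc2ccccc21`: 91.5%

In a functional assay on J774.A1 cells (Mus musculus) for inhibition, read by immunoassay, with a stated time of 12 h, tested at 30 uM (on this read-out higher numbers stand for more inhibition at the one concentration tested (going by the name of the read-out) and lower numbers for less inhibition), compound 3 gives 91.5% and stands highest of the three measured compounds. The two steps leading to it are both large: a number 49.4 percentage points higher from compound 1 to compound 3 (beyond the scatter), and a number 47.9 percentage points higher from compound 2 to compound 3 (beyond the scatter). Compound 4 `O=C1CC(c2ccccc2OCc2cccc(F)c2)Oc2ccccc21` is the next compound to be tested; it differs from compound 3 by fluoro in place of hydrogen on an aromatic carbon.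

For the measured compounds named here, the step that bears on this change is the one a number 49.4 percentage points higher from compound 1 to compound 3 (beyond the scatter), since compound 1 also carries a fluoro on the same benzyl ring, only at a different place. Read backward, it suggests that putting a fluoro back onto that ring costs a great deal. Whether the new place, meta to a large group, behaves like the old one cannot be told from a single step, so the size of the drop is uncertain. A downward step in this assay is nonetheless expected, a number 33.5 percentage points lower from compound 3 to compound 4 (beyond the scatter). Compound 4 is therefore estimated to give 58%, within a range from 35% to 85%.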

Compound 4, a percentage reported as inhibition, at one concentration (the size of the read-out at that concentration, not a potency): 92.7%
Compound 4: middle estimate off by 34.7 percentage points, on the low side; measured number above the stated range.
By their numbers in this assay, from the lowest: compounds 1 and 2 (each within the scatter of the next); then compounds 3 and 4 (each within the scatter of the next).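

In this assay, a fluoro on the benzyl ring does not by itself lower the number: the 3-fluorobenzyl group and the plain benzyl group cannot be told apart (a number 1.2 percentage points higher from compound 3 to compound 4 (within the scatter)). The place of the fluoro on that ring does count, since exchanging 4-fluorophenyl for 3-fluorophenyl is a large step (a number 50.6 percentage points higher from compound 1 to compound 4 (beyond the scatter)), so the earlier low result of compound 1 cannot be read as a penalty on fluoro in general. The isobutyl chain of compound 2 also stays far from the 3-fluorophenyl group (a number 49.1 percentage points higher from compound 2 to compound 4 (beyond the scatter)).

No measurement shown here explains why the place of the fluoro matters so much. On these data alone, it also remains open whether a chloro or a methoxy in place of the fluoro of compound 4 would keep the number high.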